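The source may report more compounds than this note shows. Statements on the series, on what has been measured and on what is new or still open speak of the compounds shown alone.

Working notes on the series. Going by the values given here, compound 1 `COc1cc(Oc2cccc(Nc3ccccc3)c2)cc(OC)c1CN[C@H](C)c1ccccc1` stands at the higher of the two numbers known so far: in a functional assay on DLD-1 cells (Homo sapiens) for inhibition, read by MTT assay, with a stated time of 72 h (on this read-out higher numbers stand for weaker inhibition and lower numbers for stronger inhibition), compound 1 gives 8570 nM. Among the compounds with values here, the only other measured member, compound 2 `COc1ccc([C@@H](C)NCc2c(OC)cc(Oc3cccc(Nc4ccccc4)c3)c(OC)c2OC)cc1`, gives 3500 nM in this assay, a gap that lies beyond the scatter; the two compounds differ in several places, so no single step connects them.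

Compound 3 `COc1cc(Oc2cccc(Nc3ccccc3)c2)cc(OC)c1CNCc1ccc(O)cc1` differs from compound 1 in one place: 4-hydroxybenzyl in place of 1-phenylethyl on an amine nitrogen. Within the data shown here, no measured pair isolates this change, so the expected step from compound 1 to compound 3 in this assay is a 1.3-fold lower number from compound 1 to compound 3 (0.12 log units; within the scatter), with no clear direction beyond the scatter. Compound 3 is estimated at 6500 nM, within 2500 nM to 17000 nM.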

Compound 3, half-maximal inhibitory concentration: 2690 nM
For compound 3 the middle estimate is 2.4-fold (0.38 log units) above the measured one; low and high end bracket the measured number.
By their numbers in this assay, from the lowest: compounds 3 and 2 (each within the scatter of the next); then compound 1.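

In this assay, the amine nitrogen proves a place where a single change moves the number beyond the scatter: 4-hydroxybenzyl in place of 1-phenylethyl gives a 3.2-fold lower number from compound 1 to compound 3 (0.50 log units; beyond the scatter). Going by these compounds alone, this is the first single-place step, but the change both removes the defined stereocentre and brings in a hydrogen-bond donor and acceptor, and this one step cannot separate these differences. No measurement on hand accounts for the step. Going by these compounds, whether plain benzyl or 4-methoxybenzyl on this nitrogen would keep the step remains open.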